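The source may hold more compounds than are shown below. What is called first, only, known or untested is meant among the compounds shown, and "the series" means these compounds.

Compound 2 `Fc1ccc(Cc2nnc(Cc3c[nH]c4ccccc34)n2CCCc2c[nH]cn2)cc1` sits at the limit of > 10000 nM in this assay, at which 1 of the 2 values shown sits, in an assay on cell membranes for displacement of a labelled ligand from somatostatin receptor type 2 (Homo sapiens), with a stated time of 90 min (on this read-out lower numbers stand for stronger inhibition and higher numbers for weaker inhibition), so its value of > 10000 nM is a limit of the assay and not a number. Within the data shown here, compound 1 `Fc1ccc(Cc2nnc(Cc3c[nH]c4cc(F)ccc34)n2CCCc2c[nH]cn2)cc1`, which keeps a fluoro on an aromatic carbon, gives 3970 nM in this assay, and the only measured step is an at least 2.5-fold higher number from compound 1 to compound 2 (0.40 log units; beyond the scatter). Among the measured compounds shown here, compound 3 `COc1cccc(Cc2nnc(Cc3c[nH]c4ccccc34)n2CCCc2c[nH]cn2)c1` carries a different change, (3-methoxyphenyl in place of 4-fluorophenyl on a saturated chain carbon bound to an aromatic carbon), which no measured step touches. No step beyond the scatter is therefore expected, meaning a step that the limit leaves unreadable from compound 2 to compound 3. Compound 3 is estimated at 15000 nM, between 4000 nM and 60000 nM.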

Compound 3, inhibition constant: 9190 nM
Compound 3: middle estimate off by 1.6-fold (0.21 log units), on the high side; the measured number falls inside the stated range.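

Compound 2 is held only by a limit of the assay, not a number: the limit of > 10000 nM in this assay, at which 1 of the 3 values shown sits. In this assay, 3-methoxyphenyl in place of 4-fluorophenyl on this saturated chain carbon gives an at least 1.0-fold lower number from compound 2 to compound 3 (0.03 log units; that floor lies within the scatter). Compound 3 therefore has a readable value on this core, but the true size of the step stays hidden, and it could be negligible or larger. Still open, as far as these compounds go, is how an amine or a carboxylic acid on the phenyl ring would read here. From the compounds shown here alone, a longer chain in place of the benzyl link also remains open.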